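Aryl swap on the sulfonyl at the cytotoxicity limit

The compounds below may be only part of what the source reports. "The series", "measured", "known", "first", "only" and "open" are said of these compounds alone.

In a functional assay on HEK293 cells (Homo sapiens) for cytotoxicity (a lower number here means that less compound is tolerated, a higher number that more compound is tolerated), compound 1 (`COc1ccc([C@H]2CC(=O)N(c3cccc(NCC4CCOC4)c3)C2)cc1OC1CCCC1`) gives > 10000 nM, which is a limit and not a number. In this assay compound 2 (`COc1ccc([C@H]2CC(=O)N(c3cccc(NS(=O)(=O)c4ccccc4Cl)c3)C2)cc1OC1CCCC1`) gives > 10000 nM, which is likewise a limit. Both measured compounds therefore stand at the limit of > 10000 nM in this assay, at which 2 of the 2 values shown sit.

Compound 3 (`COc1ccc([C@H]2CC(=O)N(c3cccc(NS(=O)(=O)c4ccc(F)cc4)c3)C2)cc1OC1CCCC1`) differs from compound 2 by 4-fluorophenyl in place of 2-chlorophenyl on a sulfonyl sulfur, with 4-fluorophenyl in place of 2-chlorophenyl on a sulfonyl sulfur.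

For the measured compounds named here, the only measured step that bears on this change is a step that the two limits leave unreadable from compound 1 to compound 2. Going by the values given here, it gives no size to carry over, and no measured step covers this exact replacement. The expectation rests on that step and on the shared limit, so no change beyond the scatter is expected in this assay, and a further limit is the likeliest report. The expected step is a step that the limit leaves unreadable from compound 2 to compound 3. For compound 3 the estimated value is 12000 nM, with an expected range of 6000 nM to 30000 nM.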

Compound 3, half-maximal cytotoxic concentration: > 10000 nM
Compound 3: a limit, no number; the forecaster's own chance of this, stated with the estimate: 85%; the middle value is on the limit's open side.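

In this assay, for the compounds shown here, compound 3 gives > 10000 nM, a limit and not a number, so no step from compound 1 or compound 2 to compound 3 can be read. The compounds shown leave open whether swapping the aryl group on the sulfonyl changes cytotoxicity at all.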